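The compounds below may be only part of what the source reports. "The series", "measured", "known", "first", "only" and "open" are said of these compounds alone.

Measured in a functional assay on KB3 cells (Homo sapiens) for antiproliferative activity, read by MTT assay, with a stated time of 96 h; a higher number here means a weaker inhibitor, a lower number a stronger inhibitor:
Compound 1 `C=C(C)[C@H]1CC(=O)C(C)=C2[C@@H](C(=O)OCC)O[C@@H](c3ccc(Cl)cc3Cl)[C@@H]21` gives 3000 nM.
Compound 2 `C=C(C)[C@H]1CC=C(C)[C@@]2(O)[C@@H]1[C@H](c1ccccc1Br)O[C@@H]2C(=O)OC` gives 5000 nM.
Compound 3 `C=C(C)[C@H]1CC(=O)C(C)=C2[C@@H](C(=O)OCC)O[C@@H](c3cccc(Br)c3)[C@@H]21` gives 30000 nM.

Among these three numbers compound 2 holds the second highest. Its value lies within the scatter of that of compound 1, so no order between the two can be claimed, while compound 3 sits beyond the scatter above it. Going by the values given here, the one step measured between compounds differing in a single place is a 10-fold higher number from compound 1 to compound 3 (1.00 log units; beyond the scatter), and it concerns the aromatic group rather than the ester.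

Compound 4 `C=C(C)[C@H]1CC=C(C)[C@@]2(O)[C@@H]1[C@H](c1ccccc1Br)O[C@@H]2C(=O)OCC1CC1` is built from compound 2 by cyclopropyl in place of hydrogen on a saturated chain carbon bound to an oxygen next to a carbonyl group. Among the compounds with values here, no measured pair differs in this place: compounds 1 and 3 carry a different ester and a different core from compound 2, and they differ from each other only in the aromatic group. The data therefore give no direct guide to how the cyclopropylmethoxycarbonyl group will read against the methoxycarbonyl group of compound 2. With nothing to point either way, the expected step of no change at the digits printed from compound 2 to compound 4 (within the scatter) is none beyond the scatter, and compound 4 is estimated at 5000 nM, within a range of 1500 nM to 16000 nM in this assay.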

Compound 4, half-maximal inhibitory concentration: 50000 nM
Beside the measured number, compound 4's estimate is 10-fold (1.00 log units) below it, outside the stated range (above it).
By their numbers in this assay, from the lowest: compounds 1 and 2 (each within the scatter of the next); then compounds 3 and 4 (each within the scatter of the next).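

In this assay, the change of methoxycarbonyl to cyclopropylmethoxycarbonyl gives a 10-fold higher number from compound 2 to compound 4 (1.00 log units; beyond the scatter), so the group on this saturated chain carbon bound to an oxygen next to a carbonyl group does affect the read-out, and the move is towards weaker inhibition. The only earlier single-place step, a 10-fold higher number from compound 1 to compound 3 (1.00 log units; beyond the scatter), concerned the aromatic group and said nothing about the ester, so this is the first measured sign that the ester end of these compounds also matters in this assay. Nothing shown here accounts for the size or direction of the new step.

As far as these compounds go, with only these two esters on this core, it remains open whether the higher number belongs to the cyclopropyl ring itself or would come with any group larger than methyl, and an ethyl ester, a butyl ester or a free carboxylic acid in the same place would help separate these readings. From the compounds shown here alone, it also remains open whether the cyclopropylmethoxycarbonyl group would produce a similar step on the core of compound 1, which carries a different ester and a different core.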